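A few compounds are considered here, and "the series" means these few. Any claim that something is new, unique, unknown or untested is made for them only; others in the source may bear on it.

Compound 1 `CCCCN(C)c1cc(C(F)(F)F)ccc1CNC(=O)C(C)c1ccc(NS(C)(=O)=O)c(F)c1` gives 1.2 nM in an assay on CHO cells for antagonist activity at transient receptor potential cation channel subfamily V member 1 (Homo sapiens), read by FLIPR; on this read-out lower numbers stand for stronger inhibition and higher numbers for weaker inhibition. Compound 2 `COc1ccc(CSc2cc(C(F)(F)F)ccc2CNC(=O)C(C)c2ccc(NS(C)(=O)=O)c(F)c2)cc1` gives 2.3 nM in this assay; the step of a 1.9-fold higher number from compound 1 to compound 2 (0.28 log units; within the scatter) keeps both within the scatter, and compound 2 stands at the higher of the two numbers shown, with compound 1 its only neighbour. Compound 3 `CC(C(=O)NCc1ccc(C(F)(F)F)cc1[N+](=O)[O-])c1ccc(NS(C)(=O)=O)c(F)c1` carries the change (nitro in place of (4-methoxybenzyl)sulfanyl on an aromatic carbon). Among the compounds with values here, only that one measured step bears on it, and it was small, so only a modest shift is expected for compound 3, estimated at 10 nM with a range from 2 nM to 50 nM. The expected step of a 4.3-fold higher number from compound 2 to compound 3 (0.64 log units; beyond the scatter) points toward a higher number.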

Compound 3, inhibition constant: "not active" (no number reported)
Nothing numeric was reported for compound 3; the estimate stays without a comparison.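

Within the data shown here, compound 3 is reported as not active in this assay without a number, and no step from compound 2 to compound 3 can be read. Left open is where compound 3 stands numerically against compound 2, and whether the nitro group alone accounts for this result. No supporting data bear on this result.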